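A few compounds are considered here, and "the series" means these few. Any claim that something is new, unique, unknown or untested is made for them only; others in the source may bear on it.

Measured in a functional assay on A549 cells (Homo sapiens) for cytotoxicity, read by sulforhodamine B assay; on this read-out higher numbers stand for weaker inhibition and lower numbers for stronger inhibition:

Compound 1 `C=C1[C@@H](OC(C)=O)C[C@@H]2[C@](C)(CO[Si](C)(C)C(C)(C)C)[C@H](OC(C)=O)CC[C@@]2(C)[C@@H]1C[C@@H](Nc1ccc(F)cc1)C1=CCOC1=O`: 4550 nM
Compound 2 `C=C1[C@@H](OC(C)=O)C[C@@H]2[C@](C)(CO[Si](C)(C)C(C)(C)C)[C@H](OC(C)=O)CC[C@@]2(C)[C@@H]1C[C@@H](Nc1ccccc1)C1=CCOC1=O`: 4500 nM
Compound 3 `C=C1[C@@H](OC(C)=O)C[C@@H]2[C@](C)(CO[Si](C)(C)C(C)(C)C)[C@H](OC(C)=O)CC[C@@]2(C)[C@@H]1C[C@@H](Nc1ccc(OC)cc1)C1=CCOC1=O`: 4810 nM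

These three compounds share one core and differ only in the aromatic ring on the amine nitrogen. Compound 3, at 4810 nM, stands level with the other two, since its gaps to both lie within the scatter.

Compound 4 `C=C1[C@@H](OC(C)=O)C[C@@H]2[C@](C)(CO[Si](C)(C)C(C)(C)C)[C@H](OC(C)=O)CC[C@@]2(C)[C@@H]1C[C@@H](Nc1cccc(OC)c1)C1=CCOC1=O` has not yet been measured. It has 3-methoxyphenyl in place of 4-methoxyphenyl on an amine nitrogen, and the two compounds have the same atoms, joined differently: 3-methoxyphenyl in place of 4-methoxyphenyl on an amine nitrogen.

For the measured compounds named here, three measured steps bear on this change. Swapping fluoro for hydrogen gave a 1.0-fold lower number from compound 1 to compound 2 (0.00 log units; within the scatter), swapping fluoro for methoxy gave a 1.1-fold higher number from compound 1 to compound 3 (0.02 log units; within the scatter), and swapping hydrogen for methoxy gave a 1.1-fold higher number from compound 2 to compound 3 (0.03 log units; within the scatter). None of them moves a group to a different place on the ring, so they are only indirect evidence for this change. Still, all three stayed within the scatter, so a large shift would be a surprise.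

The expected change is a 1.0-fold lower number from compound 3 to compound 4 (0.01 log units; within the scatter), which means no step beyond the scatter is expected, in either direction. For compound 4 the estimated value is 4700 nM, with an expected range of 3000 nM to 7300 nM.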

Compound 4, half-maximal inhibitory concentration: 17200 nM
Compound 4: middle estimate off by 3.7-fold (0.56 log units), on the low side; the measured number lies above the stated range.
By their numbers in this assay, from the lowest: compounds 2, 1 and 3 (each within the scatter of the next); then compound 4.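

In this assay, for the compounds shown here, moving the methoxy group from 4-methoxyphenyl to 3-methoxyphenyl on the amine nitrogen gave a 3.6-fold higher number from compound 3 to compound 4 (0.55 log units; beyond the scatter) and so showed something the earlier compounds could not: with the ring's atoms unchanged, the place of the methoxy group on it can shift the number beyond the scatter, whereas swapping fluoro, hydrogen and methoxy left the numbers level. Compound 4 also stands apart from the other two rings, with a 3.8-fold higher number from compound 2 to compound 4 (0.58 log units; beyond the scatter) and a 3.8-fold higher number from compound 1 to compound 4 (0.58 log units; beyond the scatter) on record, which makes it the weakest inhibitor of the four and 3-methoxyphenyl the only ring here that departs from the shared level. Nothing available on these compounds accounts for this shift, so the data show its size but not its cause.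

From the compounds shown here alone, it stays open whether the weaker inhibition belongs to methoxy itself or to any group at that place, which a chloro or hydroxyl group at the place methoxy holds in 3-methoxyphenyl could help to separate. Going by these compounds, it also stays open whether the same difference between the two methoxyphenyl rings would appear with a free hydroxyl in place of the silyl ether on the shared core.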